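This account rests on a few compounds, and the source may have more. Where it says the series, first, only, none or still open, it means among the compounds named here.

In a functional assay on DU-145 cells (Homo sapiens) for inhibition, read by trypan blue exclusion, with a stated time of 96 h (a lower number here means a stronger inhibitor of growth, a higher number a weaker inhibitor of growth), compound 1 `O=C(/C(=C\c1ccc(Cl)cc1)S(=O)(=O)c1ccc(Br)cc1)c1ccc(Br)cc1` gives 50000 nM, compound 2 `COc1ccc(/C=C(\C(=O)c2ccc(Br)cc2)S(=O)(=O)c2ccc(Br)cc2)c(F)c1` gives 10000 nM and compound 3 `O=C(/C(=C\c1c[nH]c2ccccc12)S(=O)(=O)c1ccc(Br)cc1)c1ccc(Br)cc1` gives 25000 nM. Two steps fix where compound 3 stands: a 2.0-fold lower number from compound 1 to compound 3 (0.30 log units; within the scatter), and a 2.5-fold higher number from compound 2 to compound 3 (0.40 log units; beyond the scatter). Compound 4 `O=C(/C(=C\c1ccc(Br)c([N+](=O)[O-])c1)S(=O)(=O)c1ccc(Br)cc1)c1ccc(Br)cc1` carries 4-bromo-3-nitrophenyl in place of 1H-indol-3-yl on a double-bonded chain carbon bound to a double-bonded chain carbon. Earlier swaps at this place bear directly on the change. The third of them is a 5.0-fold lower number from compound 1 to compound 2 (0.70 log units; beyond the scatter), so none went beyond a modest size. No shift beyond the scatter is therefore expected, and the estimated step is a 1.2-fold higher number from compound 3 to compound 4 (0.08 log units; within the scatter). For compound 4 the expected value is 30000 nM, within an estimated range of 9000 nM to 80000 nM.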

Compound 4, concentration for 50% growth inhibition: 10000 nM
For compound 4 the middle estimate is 3.0-fold (0.48 log units) above the measured one, within the range that was stated.
By their numbers in this assay, from the lowest: compounds 2 and 4 (each within the scatter of the next); then compounds 3 and 1 (each within the scatter of the next).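

Compound 4 shows that the 2-fluoro-4-methoxyphenyl group is not alone at this place on a double-bonded chain carbon, since a differently substituted phenyl gives no change at the digits printed from compound 2 to compound 4 (within the scatter) in this assay with no fluorine or methoxy present. The 4-bromo-3-nitrophenyl group also improves on both other groups, with a 2.5-fold lower number from compound 3 to compound 4 (0.40 log units; beyond the scatter) and a 5.0-fold lower number from compound 1 to compound 4 (0.70 log units; beyond the scatter) in that same read-out. Two unlike phenyl groups thus share one level here, and it sits below the numbers of compound 1 and compound 3.

From the compounds shown here alone, whether a phenyl carrying an amine or a carboxylic acid at this place would hold that level stays open. The data offer nothing that accounts for these differences.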